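This account rests on a few compounds, and the source may have more. Where it says the series, first, only, none or still open, it means among the compounds named here.

- compound 1 `CCNc1nc(Nc2ccc3c(c2)NC(=O)COC3(C)C)nc2ccoc12` gives 91.7 mL/min/kg in an ADME assay on microsomes (Homo sapiens) for pharmacokinetics; a higher number here means faster removal of the compound, a lower number slower removal
- compound 2 `CCCNc1nc(Nc2ccc3c(c2)NC(=O)COC3(C)C)nc2ccoc12` gives 307 mL/min/kg in this assay

Compound 2 has the higher number of the two, and compound 1 is its nearest neighbour. Compound 3 `CC(C)CNc1nc(Nc2ccc3c(c2)NC(=O)COC3(C)C)nc2ccoc12` follows from compound 2 by the change (methyl in place of hydrogen on a saturated chain carbon bound to two saturated chain carbons), methyl in place of hydrogen on a saturated chain carbon bound to two saturated chain carbons, so propylamino becomes isobutylamino. Going by the values given here, one measured step bears on this, also a methyl on a saturated chain carbon: a 3.3-fold higher number from compound 1 to compound 2 (0.52 log units; beyond the scatter). A single step is thin support, so a smaller rise in the same direction is expected in this assay. The expected step is a 1.5-fold higher number from compound 2 to compound 3 (0.17 log units; within the scatter). For compound 3 the estimate is 450 mL/min/kg, with an expected range from 200 mL/min/kg to 900 mL/min/kg.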

Compound 3, clearance: 507 mL/min/kg
For compound 3 the middle estimate is 1.1-fold (0.05 log units) below the measured one; the range from low to high includes it.
By their numbers in this assay, from the lowest: compound 1; then compounds 2 and 3 (each within the scatter of the next).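

Methyl in place of hydrogen on a saturated chain carbon bound to two saturated chain carbons gives a 1.7-fold higher number from compound 2 to compound 3 (0.22 log units; within the scatter) in this assay, so compound 2 and compound 3 cannot be told apart. Isopropyl in place of methyl on a saturated chain carbon bound to a nitrogen on an aromatic ring, taken as one change, gives a 5.5-fold higher number from compound 1 to compound 3 (0.74 log units; beyond the scatter). Nothing available explains either step. Still open, going by these compounds, is how a hydroxyl or an amine on this chain, or a cyclopropyl group in place of the isopropyl, would read in this assay.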